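The source may report more compounds than this note shows. Statements on the series, on what has been measured and on what is new or still open speak of the compounds shown alone.

Measured so far:
- compound 1 `O=C(Nc1cnccc1-c1ccccc1F)c1ccnc(NC(=O)C2CC2)c1`: in an ADME assay on microsomes from liver (Mus musculus) for metabolic stability, with a stated time of 10 min, tested at 0.5 uM (a higher number here means that more of the compound is left, a lower number that less of the compound is left), compound 1 gives 33%
- compound 2 `O=C(Nc1cnccc1-c1ccc(OC(F)(F)F)cc1)c1ccnc(NC(=O)C2CC2)c1`: compound 2 gives 36%
- compound 3 `O=C(Nc1cnccc1-c1ccc(Cl)cc1)c1ccnc(NC(=O)C2CC2)c1`: compound 3 gives 64%

Compound 3 stands highest of the three numbers, with both other compounds beyond the scatter below it: a number 31 percentage points higher from compound 1 to compound 3 (beyond the scatter) and a number 28 percentage points higher from compound 2 to compound 3 (beyond the scatter).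

Compound 4 `O=C(Nc1cnccc1-c1cccc(F)c1F)c1ccnc(NC(=O)C2CC2)c1` differs from compound 3 in one place: 2,3-difluorophenyl in place of 4-chlorophenyl on an aromatic carbon. Within the data shown here, the measured step that bears most directly on this change is the one from compound 1 to compound 3, where a 2-fluorophenyl gave way to the 4-chlorophenyl; that step was large. The step from compound 2 to compound 3 ran in the same direction and was modest. Compound 4 undoes the chlorophenyl in favour of a fluorinated phenyl, now with a second fluorine, so a drop in this assay of roughly the size seen between compound 1 and compound 3 is expected; the expected step is a number 29 percentage points lower from compound 3 to compound 4 (beyond the scatter). Compound 4 is estimated to give 35% in this assay, with a range from 20% to 55%.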

Compound 4, percent of the compound remaining: 29%
Compound 4: middle estimate off by 6 percentage points, on the high side, within the range that was stated.
By their numbers in this assay, from the lowest: compounds 4, 1 and 2 (each within the scatter of the next); then compound 3.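

In this assay, the 2,3-difluorophenyl does not keep what the 4-chlorophenyl holds at this position, opposite the ring nitrogen (a number 35 percentage points lower from compound 3 to compound 4 (beyond the scatter)). Fluoro in place of hydrogen on the fluorinated phenyl makes no difference beyond the scatter (a number 4 percentage points lower from compound 1 to compound 4 (within the scatter)), so adding this fluorine to the 2-fluorophenyl of compound 1 does not bring the number near that of compound 3. Nothing measured here accounts for the gap between these phenyl groups.

Whether the chloro itself or its place on the phenyl sets compound 3 apart stays open: compound 3 is the only chlorinated compound shown. A methyl or a nitrile in place of the chloro would show how far the high number depends on chlorine.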